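The compounds below may be only part of what the source reports. "The series", "measured", "known", "first", "only" and "open" are said of these compounds alone.

Compound 3 `Cc1ccc(C(=O)Nc2cccc(C(F)(F)F)c2)cc1-c1ccc2c(-c3cnn(C(C)C)c3)n[nH]c2c1` gives 7.7 nM in an assay on isolated protein for inhibition of Discoidin domain-containing receptor 2 (Homo sapiens), read by ELISA, with a stated time of 60 min (on this read-out higher numbers stand for weaker inhibition and lower numbers for stronger inhibition), the highest of the three numbers shown, though the gaps to compound 1 `Cc1ccc(C(=O)Nc2cccc(C(F)(F)F)c2)cc1-c1ccc2c(-c3ccc(C(=O)N4CCN(C)CC4)cc3)n[nH]c2c1` at 6.5 nM and to compound 2 `Cc1ccc(C(=O)Nc2cccc(C(F)(F)F)c2)cc1-c1ccc2c(-c3cnn(C)c3)n[nH]c2c1` at 4.4 nM both lie within the scatter. For the measured compounds named here, the only measured step that alters just the group on the aromatic nitrogen is a 1.8-fold higher number from compound 2 to compound 3 (0.24 log units; within the scatter), a step that stays within the scatter. Compound 4 `Cc1ccc(C(=O)Nc2cccc(C(F)(F)F)c2)cc1-c1ccc2c(-c3cnn(CC(=O)N(C)C)c3)n[nH]c2c1` differs from compound 3 by (dimethylcarbamoyl)methyl in place of isopropyl on an aromatic nitrogen. Going by the values given here, that single step is the only one bearing on this change; the group that enters has no counterpart among the measured compounds, so the data give no direct guide to it. Because a 1.8-fold higher number from compound 2 to compound 3 (0.24 log units; within the scatter) stayed within the scatter, compound 4 is expected to sit close to compound 3, with a 1.0-fold higher number from compound 3 to compound 4 (0.02 log units; within the scatter) and no step beyond the scatter in this assay. The estimated value for compound 4 is 8 nM, with a range from 3 nM to 22 nM.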

Compound 4, half-maximal inhibitory concentration: 2.7 nM
For compound 4 the middle estimate is 3.0-fold (0.47 log units) above the measured one; the measured number lies below the stated range.
By their numbers in this assay, from the lowest: compounds 4, 2, 1 and 3 (each within the scatter of the next, the first and the last beyond it).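

In this assay, for the compounds shown here, the move from isopropyl to (dimethylcarbamoyl)methyl on the aromatic nitrogen gives (a 2.9-fold lower number from compound 3 to compound 4 (0.46 log units; beyond the scatter)), the first step at this position to pass beyond the scatter, though only modestly. Set against the methyl group, the same chain gives (a 1.6-fold lower number from compound 2 to compound 4 (0.21 log units; within the scatter)), so the dimethylcarbamoyl end does not separate from methyl in this assay. The position therefore accepts a chain of this size carrying a carbonyl without any loss, and the isopropyl group, not the new chain, is what stands apart from compound 4.

Going by these compounds, whether an amine, a carboxylic acid or a longer chain at this nitrogen would stay in the same range remains open, as does whether the carbonyl itself matters. The data offer no explanation for the step from isopropyl to the new chain.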